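Replacing a Chain Hydroxy with Methylsulfanyl

The source may report more compounds than this note shows. Statements on the series, on what has been measured and on what is new or still open speak of the compounds shown alone.

Measured in a functional assay on P388 cells (Mus musculus) for cytotoxicity; a lower number here means a stronger inhibitor, a higher number a weaker inhibitor:
Compound 1 `COc1ccc(C[C@H]2C(=O)N[C@@H](C)C(=O)N(C)[C@H]3Cc4ccc(cc4)Oc4cc(ccc4OC)C[C@@H](C(=O)N[C@H](C)C(=O)N[C@@H](CCCN=[N+]=[N-])C(=O)N2C)N(C)C3=O)cc1`: 35.5 nM
Compound 2 `COc1ccc(C[C@H]2C(=O)N[C@@H](C)C(=O)N(C)[C@H]3Cc4ccc(cc4)Oc4cc(ccc4OC)C[C@@H](C(=O)N[C@H](C)C(=O)N[C@@H](CCO)C(=O)N2C)N(C)C3=O)cc1`: 60.3 nM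

Compound 2 has a single measured neighbour, and the two values lie within the scatter of each other. Compound 3 `COc1ccc(C[C@H]2C(=O)N[C@@H](C)C(=O)N(C)[C@H]3Cc4ccc(cc4)Oc4cc(ccc4OC)C[C@@H](C(=O)N[C@H](C)C(=O)N[C@@H](CCSC)C(=O)N2C)N(C)C3=O)cc1` carries methylsulfanyl in place of hydroxy on a saturated chain carbon, two bonds along the chain from a saturated ring carbon. Going by the values given here, the one measured step at this place, which produced compound 2, is a 1.7-fold higher number from compound 1 to compound 2 (0.23 log units; within the scatter). On that single step, no change beyond the scatter is expected in this assay. The expected step is a 1.3-fold lower number from compound 2 to compound 3 (0.13 log units; within the scatter). Compound 3 is estimated at 45 nM, with an expected range of 18 nM to 110 nM.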

Compound 3, half-maximal inhibitory concentration: 20.4 nM
The estimate for compound 3 lay 2.2-fold (0.34 log units) above the measured number; measured number inside the range.
By their numbers in this assay, from the lowest: compounds 3, 1 and 2 (each within the scatter of the next, the first and the last beyond it).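

In this assay this position now shows a step beyond the scatter, a 3.0-fold lower number from compound 2 to compound 3 (0.47 log units; beyond the scatter) on exchanging hydroxy for methylsulfanyl, while the earlier step here stayed within it. Methylsulfanyl in place of azidomethyl gives a 1.7-fold lower number from compound 1 to compound 3 (0.24 log units; within the scatter) and so separates the two groups no more than that earlier step did. Nothing available accounts for this difference between the steps.

On these data alone, whether a methoxy group, an amine or a carboxylic acid at this place would fall with compound 3 or with compound 2 stays open.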